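Trifluoromethyl for Chloro on a Shared Anilino Core

A few compounds are considered here, and "the series" means these few. Any claim that something is new, unique, unknown or untested is made for them only; others in the source may bear on it.

Three compounds built on one core were tested in a functional assay on MCF7 cells (Homo sapiens) for inhibition, read by MTT assay, with a stated time of 72 h; a higher number here means a weaker inhibitor, a lower number a stronger inhibitor. Compound 1 `CC(C)c1ccc(-c2nc(SCc3cn(CC(=O)NC(=O)Nc4ccccn4)nn3)nc(Nc3cccc(Cl)c3)c2C#N)cc1` gives 18000 nM. Compound 2 `CC(C)c1ccc(-c2nc(SCc3cn(CC(=O)NC(=O)Nc4ccccn4)nn3)nc(Nc3cccc(C(F)(F)F)c3)c2C#N)cc1` carries trifluoromethyl in place of chloro on an aromatic carbon and gives 8620 nM; the step of a 2.1-fold lower number from compound 1 to compound 2 (0.32 log units; beyond the scatter) is the only one among these compounds that goes beyond the scatter. Compound 3 `Cc1ccc(-c2nc(SCc3cn(CC(=O)NC(=O)Nc4ccccn4)nn3)nc(Nc3cccc(Cl)c3)c2C#N)cc1` differs from compound 1 by methyl in place of isopropyl on an aromatic carbon, and compound 3 gives 14900 nM; the step of a 1.2-fold lower number from compound 1 to compound 3 (0.08 log units; within the scatter) lies within the scatter, so compounds 1 and 3 cannot be ordered. Compound 4 `Cc1ccc(-c2nc(SCc3cn(CC(=O)NC(=O)Nc4ccccn4)nn3)nc(Nc3cccc(C(F)(F)F)c3)c2C#N)cc1` has not yet been measured in this assay; it differs from compound 3 by trifluoromethyl in place of chloro on an aromatic carbon, the same change that takes compound 1 to compound 2, at the same place on the ring. The change occurs twice among the four compounds. Because the step of a 2.1-fold lower number from compound 1 to compound 2 (0.32 log units; beyond the scatter) was modest but real, a step of similar size is expected on the core of compound 3, namely a 2.0-fold lower number from compound 3 to compound 4 (0.30 log units; within the scatter). Compound 4 is therefore estimated at 7500 nM, with a likely range from 3500 nM to 16000 nM.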

Compound 4, half-maximal inhibitory concentration: 6120 nM
Compound 4: the middle estimate sits 1.2-fold (0.09 log units) above what was measured; the measured number falls inside the stated range.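

In this assay, trifluoromethyl in place of chloro again gives a step beyond the scatter on the second core, a 2.4-fold lower number from compound 3 to compound 4 (0.39 log units; beyond the scatter), and this step agrees with the one on the first core: the same change on two cores in this assay, a 2.1-fold lower number (0.32 log units; beyond the scatter) from compound 1 to compound 2 and a 2.4-fold lower number (0.39 log units; beyond the scatter) from compound 3 to compound 4, 1.2-fold (0.07 log units) apart, within the scatter of two such steps. Methyl in place of isopropyl, seen here as a 1.4-fold lower number from compound 2 to compound 4 (0.15 log units; within the scatter), stays within the scatter on both cores, so the two compounds of each pair cannot be ordered: the same change on two cores in this assay, a 1.2-fold lower number (0.08 log units; within the scatter) from compound 1 to compound 3 and a 1.4-fold lower number (0.15 log units; within the scatter) from compound 2 to compound 4, 1.2-fold (0.07 log units) apart, within the scatter of two such steps. Together these results show that the trifluoromethyl change carried over between two cores that differ only by methyl and isopropyl, but they do not show that it would carry over to a core altered elsewhere, and they give no reason for the step.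

The compounds shown leave open how other groups at the same place on the ring, such as a methoxy group, an amine or a carboxylic acid, would read in this assay. They also leave open what a longer chain, such as butyl, would do in place of the isopropyl group.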